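Fluoro for hydrogen in a mouse liver microsome clearance series

The source may report more compounds than this note shows. Statements on the series, on what has been measured and on what is new or still open speak of the compounds shown alone.

Compound 1 `Fc1cc(Cl)ccc1-c1ccc(Cn2nnc3ccccc32)cn1` is the reference for one pair. In an ADME assay on microsomes from liver (Mus musculus, strain NMRI) for metabolic stability, tested at 2.5 uM (on this read-out lower numbers stand for slow clearance and higher numbers for fast clearance), compound 1 gives 3.4 mL/min/g. Compound 2 `Fc1ccc2nnn(Cc3ccc(-c4ccc(Cl)cc4F)nc3)c2c1` carries the change (fluoro in place of hydrogen on an aromatic carbon), and in this assay compound 2 gives 2.2 mL/min/g; the step is a 1.5-fold lower number from compound 1 to compound 2 (0.19 log units; within the scatter).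

Compound 3 `Clc1ccc(Cn2nnc3c(Br)cccc32)cc1` has a different core; the difference between the two cores is not broken down here. In this assay compound 3 gives 2 mL/min/g. Compound 4 `Fc1cc(Cl)ccc1Cn1nnc2c(Br)cccc21` is not yet measured and differs from compound 3 by fluoro in place of hydrogen on an aromatic carbon. The change is the same kind of change as that from compound 1 to compound 2, but the place differs: here the fluoro enters ortho to a large group and meta to a chloro group, whereas in compound 2 it sits on a ring that is part of a fused system of two rings, meta and para to a fused ring.

Going by the values given here, the step from compound 3 to compound 4 is expected to be a 1.3-fold lower number from compound 3 to compound 4 (0.10 log units; within the scatter), resting on the single earlier step of a 1.5-fold lower number from compound 1 to compound 2 (0.19 log units; within the scatter), which lay within the scatter. Compound 4 is therefore estimated at 1.6 mL/min/g, between 0.9 mL/min/g and 3.2 mL/min/g.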

Compound 4, intrinsic clearance in a liver preparation (reported as CLH), per the amount of preparation that the assay uses: 1.3 mL/min/g
Compound 4: middle estimate off by 1.2-fold (0.09 log units), on the high side; low and high end bracket the measured number.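

In this assay the fluoro for hydrogen change on the core of compound 3 gives a 1.5-fold lower number from compound 3 to compound 4 (0.19 log units; within the scatter) and matches the earlier step on the core of compound 1: the same change on two cores in this assay, a 1.5-fold lower number (0.19 log units; within the scatter) from compound 1 to compound 2 and a 1.5-fold lower number (0.19 log units; within the scatter) from compound 3 to compound 4, 1.0-fold (0.00 log units) apart, within the scatter of two such steps.

The change therefore reads the same on these two cores, even though the fluoro enters a different place on each, and on this evidence a step seen on one of them would have served as a guide to the other. It does not show a real shift in clearance, since each step on its own lies within the scatter, and agreement between two small steps cannot establish a shared effect. Two pairs also give no rule for other cores or other places, and they give no reason for the agreement.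

Still open, as far as these compounds go, is whether a larger step appears with a group other than fluoro at the same place, such as a methoxy group, a nitrile, an amine or a carboxylic acid. Also open, from the compounds shown here alone, is whether fluoro gives a matching step at other places on either core.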